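Adding a Second Chloro Group: Expected Cytotoxicity of Compound 4

A few compounds are considered here, and "the series" means these few. Any claim that something is new, unique, unknown or untested is made for them only; others in the source may bear on it.

Three compounds have been measured in an ADME assay on MT4 cells (Homo sapiens) for cytotoxicity, read by MTT assay, with a stated time of 5 days; on this read-out lower numbers stand for higher toxicity in this test and higher numbers for lower toxicity in this test:

Compound 1, `O=C1N(Cc2ccccc2Cl)c2cccn2S(=O)(=O)N1Cc1cccc(Br)c1`, gives > 260000 nM, which is a limit of the assay.
Compound 2, `N#Cc1ccccc1CN1C(=O)N(Cc2ccccc2)S(=O)(=O)n2cccc21`, gives > 318000 nM, which is also a limit of the assay.
Compound 3, `O=C1N(Cc2ccccc2Cl)c2cccn2S(=O)(=O)N1Cc1cccc(F)c1`, gives 231000 nM.

Compound 3 is therefore the only one of the three with a number rather than a limit; it is measured where the other two reach the ceiling of this assay (the limit of > 260000 nM in this assay, at which 1 of the 3 values shown sits; (the limit of > 318000 nM in this assay, at which 1 of the 3 values shown sits)). Within the data shown here, the single measured step, an at least 1.1-fold lower number from compound 1 to compound 3 (0.05 log units; that floor lies within the scatter), lies within the scatter and concerns a different halogen exchange than the one now considered.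

Compound 4, `O=C1N(Cc2ccc(Cl)cc2Cl)c2cccn2S(=O)(=O)N1Cc1cccc(F)c1`, differs from compound 3 by chloro in place of hydrogen on an aromatic carbon. Among the measured compounds shown here, no measured step matches this change, so the only guide is that all three measured compounds sit at or near the ceiling of this assay and that the one measured step stayed within the scatter. Compound 4 is therefore expected to show a 1.0-fold lower number from compound 3 to compound 4 (0.00 log units; within the scatter), that is, no step beyond the scatter. The estimate for compound 4 in this assay is 230000 nM, with a range from 100000 nM to 500000 nM.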

Compound 4, half-maximal cytotoxic concentration: > 249000 nM
Compound 4: a limit, no number (the forecaster's own chance of this, stated with the estimate: 50%); middle value at least 1.0-fold (0.03 log units) away from the limit.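

From the compounds shown here alone, the change from 2-chlorobenzyl to 2,4-dichlorobenzyl, with the new chloro group meta to the existing chloro group and para to a large group, gives an at least 1.0-fold higher number from compound 3 to compound 4 (0.03 log units; that floor lies within the scatter), and only that floor can be read, so the true size of the step stays unknown. Among these compounds, the only earlier step, an at least 1.1-fold lower number from compound 1 to compound 3 (0.05 log units; that floor lies within the scatter), concerned a halogen exchange on the other aromatic ring, whereas this result is the first to probe the ring that carries the 2-chloro group and shows that a second chloro group there does not bring a measured number below the limit reached in this assay. For compound 4 the read-out is therefore a limit and not a number: the limit of > 249000 nM in this assay, at which 1 of the 4 values shown sits.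

Going by these compounds, how far the true value of compound 4 lies from its limit remains open, and so does whether the added chloro group changes the read-out at all. Also open, on these data alone, is whether an amine, a carboxylic acid or a longer chain in this same place would give a number clearly apart from those of compound 3 and compound 4 in this assay.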